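Replacing the 3-carbamoylphenyl group of compound 2

This account rests on a few compounds, and the source may have more. Where it says the series, first, only, none or still open, it means among the compounds named here.

compound 1 `COc1ccc(-c2nc(C)oc2C(=O)N2CCN(c3cccc(Cl)c3)CC2)cc1OC` gives "not active" (no number reported)
compound 2 `Cc1nc(-c2ccccc2)c(C(=O)N2CCN(c3cccc(C(N)=O)c3)CC2)o1` gives 71 nM
compound 3 `CCc1nc(-c2ccc(F)cc2)c(C(=O)N2CCN(c3cccc(Cl)c3)CC2)o1` gives 169 nM

These three results come from a functional assay on HL-60 cells (Homo sapiens) for inhibition, read by MTT assay, with a stated time of 72 h (on this read-out higher numbers stand for weaker inhibition and lower numbers for stronger inhibition), and form a very small set. Compound 2 holds the lower of the two actual numbers, so it shows the stronger inhibition. Compound 3 stands above it by more than the usual scatter, while compound 1 gave no number at all.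

The next compound to be tested is compound 4 `Cc1ccc(N2CCN(C(=O)c3oc(C)nc3-c3ccccc3)CC2)c(C)c1`, which carries 2,4-dimethylphenyl in place of 3-carbamoylphenyl on an amine nitrogen in a ring and keeps the rest of compound 2 unchanged.

Among the measured compounds shown here, no measured pair changes this group alone, so the evidence is indirect. Compound 3 at 169 nM and compound 1 at "not active" (no number reported) both lack the 3-carbamoylphenyl group, although they also differ from compound 2 elsewhere. On that thin basis, weaker inhibition is the expected direction, with a higher number in this assay than for compound 2.

The expected size is a 3.5-fold higher number from compound 2 to compound 4 (0.55 log units; beyond the scatter) as an estimate, which would lie beyond the scatter. For compound 4 the estimated value is 250 nM and the expected range runs from 50 nM to 1200 nM in this wide estimate.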

Compound 4, half-maximal inhibitory concentration: 101 nM
The estimate for compound 4 lay 2.5-fold (0.39 log units) above the measured number, and the stated range covers the measured number.
By their numbers in this assay, from the lowest: compounds 2, 4 and 3 (each within the scatter of the next, the first and the last beyond it).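

In this assay, putting 2,4-dimethylphenyl in place of 3-carbamoylphenyl on the amine nitrogen in the ring gives a 1.4-fold higher number from compound 2 to compound 4 (0.15 log units; within the scatter) and so leaves the two compounds indistinguishable in this read-out. Among the compounds shown here, compounds 1 and 3 also differ from compound 2 elsewhere, so this is the first pair to isolate this position, and it shows that the 3-carbamoylphenyl group is not required here for a number of this size. The entering group has 0 hydrogen-bond donors and 0 hydrogen-bond acceptors, against 1 of each in the group it replaces, yet the data offer nothing that explains why the two compounds read alike.

As far as these compounds go, it remains open whether either methyl group of 2,4-dimethylphenyl contributes on its own, as a plain phenyl or a phenyl with a single methyl at this place would be needed to tell. It is also unknown how far the position accepts other kinds of group, such as a phenyl carrying a carboxylic acid or an amine in place of the carbamoyl group.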